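Chloro on the indole ring of a leukotriene antagonist

The compounds below may be only part of what the source reports. "The series", "measured", "known", "first", "only" and "open" are said of these compounds alone.

Measured compounds:
- compound 1: `CCCCOC(=O)Nc1ccc2ccn(Cc3ccc(C(=O)O)cc3OC)c2c1`; 155 nM
- compound 2: `COc1cc(C(=O)O)ccc1Cn1ccc2ccc(NC(=O)OC3CCCC3)cc21`; 15.7 nM

In a functional assay on trachea for agonist activity at cysteinyl leukotriene receptor (Homo sapiens) (a lower number here means a stronger inhibitor, a higher number a weaker inhibitor), compound 1 gives 155 nM, the highest number of the two measured, while compound 2 gives 15.7 nM. Among the compounds with values here, the one measured step, a 9.9-fold lower number from compound 1 to compound 2 (0.99 log units; beyond the scatter), concerns the ester end of the carbamate, not the ring that is changed here.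

Compound 3, `CCCCOC(=O)Nc1ccc2c(Cl)cn(Cc3ccc(C(=O)O)cc3OC)c2c1`, is not yet measured. It differs from compound 1 by chloro in place of hydrogen on an aromatic carbon, on an aromatic carbon of a five-membered aromatic ring with one nitrogen, part of a fused system of two rings. Within the data shown here, no measured step touches this position, so the step from compound 1 to compound 2 offers no guide to its size or direction. With nothing in the measured pairs to point either way, the expected number for compound 3 in this assay is taken close to that of compound 1, a step of a 1.4-fold lower number from compound 1 to compound 3 (0.15 log units; within the scatter), which is within the scatter. The estimate for compound 3 is therefore 110 nM, with a range from 30 nM to 400 nM.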

Compound 3, antagonist equilibrium constant: 92.7 nM
Compound 3: middle estimate off by 1.2-fold (0.07 log units), on the high side; measured number inside the range.
By their numbers in this assay, from the lowest: compound 2; then compounds 3 and 1 (each within the scatter of the next).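

In this assay, the step of a 1.7-fold lower number from compound 1 to compound 3 (0.22 log units; within the scatter) shows that this position, two ring bonds from the ring nitrogen and two from the ring atom that bears a large group, accepts chloro in place of hydrogen on the core of compound 1 with no change that can be told from the scatter. Within the data shown here, the earlier compounds showed only that the number responds to the group on the carbamate oxygen, where a 9.9-fold lower number from compound 1 to compound 2 (0.99 log units; beyond the scatter) is printed as beyond the scatter; this is the first reading at the ring position, and here the same kind of shift does not appear. Nothing at hand explains why the number at this position behaves as it does.

The compounds shown leave open whether a group other than chloro at this same place, such as bromo, methyl, a nitrile or an amine, would also leave the number within the scatter of compound 1. They also leave open what chloro here would do on the core of compound 2, which carries cyclopentyl in place of butyl on the carbamate oxygen.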